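Drawing the stereocentre of compound 2 as S

The source may hold more compounds than are shown below. What is called first, only, known or untested is meant among the compounds shown, and "the series" means these compounds.

In a functional assay on the whole organism with Mus musculus as the target, in the maximal electroshock model, with a stated time of 0.5 h (a higher number here means that more compound is needed for the effect, a lower number that less compound is needed), compound 2 (`CCC1(c2ccccc2)OC(=O)N(C)C1=O`) gives 124 mg/kg. Compound 1 (`CC[C@]1(c2ccccc2)OC(=O)N(C)C1=O`) gives 122 mg/kg and compound 3 (`CCC1(c2ccccc2)OC(=O)NC1=O`) gives 86 mg/kg, so compound 2 lies within the scatter of both. Compound 4 (`CC[C@@]1(c2ccccc2)OC(=O)N(C)C1=O`) is still unmeasured. Its difference from compound 2 is the two compounds have the same atoms and bonds; at least one stereo element is drawn with a configuration in one of them and without one in the other: 1 of 1 stereo elements differ; a stereocentre at a saturated ring carbon is drawn without a configuration in compound 2 and S in compound 4. For the measured compounds named here, the nearest precedent is a 1.0-fold higher number from compound 1 to compound 2 (0.01 log units; within the scatter), which involves the same stereocentre, drawn R in compound 1. The other measured change, a 1.4-fold lower number from compound 2 to compound 3 (0.16 log units; within the scatter), is hydrogen in place of methyl on an amide-type nitrogen in a ring, and it bears only loosely on this question. No step beyond the scatter is therefore expected in this assay. The expected step is a 1.0-fold higher number from compound 2 to compound 4 (0.00 log units; within the scatter). For compound 4 the estimated value is 125 mg/kg, with an expected range of 80 mg/kg to 190 mg/kg.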

Compound 4, dose for half-maximal effect: 188 mg/kg
The estimate for compound 4 lay 1.5-fold (0.18 log units) below the measured number; low and high end bracket the measured number.
By their numbers in this assay, from the lowest: compounds 3, 1, 2 and 4 (each within the scatter of the next, the first and the last beyond it).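

In this assay the step of a 1.5-fold higher number from compound 1 to compound 4 (0.19 log units; within the scatter) gives the first direct comparison of R and S at the stereocentre at a saturated ring carbon, and the two drawn forms do not separate beyond the scatter: the fact that compounds 1 and 4 differ only in the configuration as drawn
The step of a 1.5-fold higher number from compound 2 to compound 4 (0.18 log units; within the scatter) also stays within the scatter, so compound 2, drawn without a configuration, cannot be told apart from compound 4 here: the fact that one of compounds 2 and 4 is drawn with a defined configuration and the other without, at the place where they differ

Going by these compounds, whether R and S stay this close with a longer chain in place of the ethyl group remains open. So does the comparison of R and S with hydrogen in place of methyl on the amide-type nitrogen.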